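Chloro in Place of Methoxy on the Phenoxy Ring

The compounds below may be only part of what the source reports. "The series", "measured", "known", "first", "only" and "open" are said of these compounds alone.

Among the measured compounds shown here, compound 3 `CNC(=O)c1cccc(Cn2nc(C)c(NC(=O)c3ccc(COc4ccc(OC)cc4)cc3)c2C)c1` gives 8000 nM in a functional assay on MIA PaCa-2 cells (Homo sapiens) for antiproliferative activity, read by MTT assay, with a stated time of 72 h (a lower number here means that less compound is needed, a higher number that more compound is needed for the effect), the highest of the three numbers so far, though both neighbours sit within the scatter: compound 1 `CNC(=O)c1cccc(Cn2nc(C)c(NC(=O)c3ccc(COc4ccccc4)cc3)c2C)c1` gives 6200 nM and compound 2 `CNC(=O)c1cccc(Cn2nc(C)c(NC(=O)c3ccc(COc4cccc(OC)c4)cc3)c2C)c1` gives 6200 nM. Compound 4 `CNC(=O)c1cccc(Cn2nc(C)c(NC(=O)c3ccc(COc4cccc(Cl)c4)cc3)c2C)c1` carries 3-chlorophenyl in place of 4-methoxyphenyl on an oxygen on a saturated carbon. For the measured compounds named here, the nearest precedent is a 1.3-fold higher number from compound 2 to compound 3 (0.11 log units; within the scatter), a move of the methoxy group around the same ring; putting that group on at all, no change at the digits printed from compound 1 to compound 2 (within the scatter) and a 1.3-fold higher number from compound 1 to compound 3 (0.11 log units; within the scatter), likewise changed nothing beyond the scatter. Going by the values given here, no chlorine-bearing analogue has been measured, so the expected step of a 1.2-fold lower number from compound 3 to compound 4 (0.09 log units; within the scatter) is set close to nothing. Compound 4 is therefore estimated at 6500 nM, with a range from 2500 nM to 16000 nM.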

Compound 4, half-maximal effective concentration: 5900 nM
For compound 4 the middle estimate is 1.1-fold (0.04 log units) above the measured one; low and high end bracket the measured number.
By their numbers in this assay, from the lowest: compounds 4, 1, 2 and 3 (each within the scatter of the next).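

Chloro is the first group on the phenoxy ring here other than methoxy, and in this assay the 3-chlorophenyl stays within the scatter of all three earlier compounds (a 1.4-fold lower number from compound 3 to compound 4 (0.13 log units; within the scatter)) (a 1.1-fold lower number from compound 2 to compound 4 (0.02 log units; within the scatter)) (a 1.1-fold lower number from compound 1 to compound 4 (0.02 log units; within the scatter)). At this place, on an oxygen on a saturated carbon, neither methoxy nor chloro is set apart from the plain ring by these numbers. No measurement shown offers an explanation for this result. The compounds shown leave open whether an amine or a carboxylic acid on that ring would take the number beyond the scatter.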